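Aryl change on the sulfonamide nitrogen, compound 3 to compound 4

This account rests on a few compounds, and the source may have more. Where it says the series, first, only, none or still open, it means among the compounds named here.

Compound 1 `CN(c1ccccc1Cl)S(=O)(=O)C1CC2OC1C(c1ccc(NC(=O)CCCCCCC(=O)O)cc1)=C2c1ccc(O)cc1` gives > 100000 nM in an ADME assay on Vero cells (Chlorocebus sabaeus) for antiproliferative activity, read by MTT assay, with a stated time of 72 h (on this read-out higher numbers stand for weaker inhibition and lower numbers for stronger inhibition), as a limit.
Compound 2 `CN(c1ccc(Cl)cc1)S(=O)(=O)C1CC2OC1C(c1ccc(NC(=O)CCCCCCC(=O)O)cc1)=C2c1ccc(O)cc1` gives > 100000 nM in this assay as a limit.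
Compound 3 `CCN(c1ccc(C)cc1)S(=O)(=O)C1CC2OC1C(c1ccc(NC(=O)CCCCCCC(=O)O)cc1)=C2c1ccc(O)cc1` gives > 100000 nM in this assay as a limit.

Compound 3 has no number, only a limit, and the series shows the limit of > 100000 nM in this assay, at which 3 of the 3 values shown sit, as its common position. Compound 4 `CCN(c1cccc(OC)c1)S(=O)(=O)C1CC2OC1C(c1ccc(NC(=O)CCCCCCC(=O)O)cc1)=C2c1ccc(O)cc1` differs by 3-methoxyphenyl in place of 4-methylphenyl on a sulfonamide nitrogen on a sulfonamide nitrogen. Within the data shown here, the steps that bear on this are a step that the two limits leave unreadable from compound 1 to compound 2 and a step that the two limits leave unreadable from compound 1 to compound 3 and a step that the two limits leave unreadable from compound 2 to compound 3 as well, so none has a size to carry over. No step beyond the scatter is expected in this assay for this change. The expected move is a number no higher from compound 3 to compound 4 (the limit leaves the size open) and is an estimate only. Compound 4 is estimated at 100000 nM (expected range 50000 nM to 200000 nM), most likely reported as a limit.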

Compound 4, half-maximal inhibitory concentration: > 100000 nM
Compound 4: a limit, no number; the forecaster's own chance of this, stated with the estimate: 90%; the middle value sits exactly at the limit.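

In this assay compound 4 gives > 100000 nM, a limit, so no step can be read among compound 1, compound 2, compound 3 and compound 4. The compounds shown leave open how far any of them lies past that limit, and whether any change on the sulfonamide nitrogen would give a measurable number.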